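This account rests on a few compounds, and the source may have more. Where it says the series, first, only, none or still open, it means among the compounds named here.

Series read in a functional assay on Raji cells (Homo sapiens) for antiproliferative activity, read by CCK-8 assay, with a stated time of 48 h; on this read-out lower numbers stand for stronger inhibition and higher numbers for weaker inhibition:

- Compound 1 `C=CC(=O)N1CCC[C@@H](n2nc(C#CCOc3ccccc3)c3c(N)ncnc32)C1`: 1800 nM
- Compound 2 `C=CC(=O)N1CCC[C@@H](n2nc(C#CCCc3ccccc3)c3c(N)ncnc32)C1`: 1620 nM
- Compound 3 `C=CC(=O)N1CCC[C@@H](n2nc(C#CCNc3ccccc3)c3c(N)ncnc32)C1`: > 40000 nM (a limit of the assay, not a number)

Compound 3 has no numerical value and stands at the limit of > 40000 nM in this assay, at which 1 of the 3 values shown sits. The next change leads to compound 4 `C=CC(=O)N1CCC[C@@H](n2nc(C#CCSc3ccccc3)c3c(N)ncnc32)C1`: phenylsulfanyl in place of anilino on a saturated chain carbon bound to a triple-bonded carbon, (phenylsulfanyl in place of anilino on a saturated chain carbon bound to a triple-bonded carbon).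

Among the compounds with values here, three measured steps bear on this change. Between the two compounds with numerical values, the exchange of phenoxy for benzyl gives a 1.1-fold lower number from compound 1 to compound 2 (0.05 log units; within the scatter). Both steps into anilino are large: an at least 22-fold higher number from compound 1 to compound 3 (1.34 log units; beyond the scatter) and an at least 24-fold higher number from compound 2 to compound 3 (1.39 log units; beyond the scatter). Among these three compounds, only the anilino compound departs from the shared level of compound 1 and compound 2. Compound 4 removes anilino, so the loss seen in an at least 22-fold higher number from compound 1 to compound 3 (1.34 log units; beyond the scatter) is expected to be largely reversed, although sulfur-linked phenyl has not yet been tested in this series. A large move toward a lower number is therefore expected in this assay. For compound 4, the expected change is an at least 20-fold lower number from compound 3 to compound 4 (1.30 log units; beyond the scatter). Compound 4 is estimated at 2000 nM, with an expected range of 700 nM to 7000 nM.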

Compound 4, half-maximal inhibitory concentration: 2720 nM
Compound 4: the middle estimate sits 1.4-fold (0.13 log units) below what was measured; the range from low to high includes it.
By their numbers in this assay, from the lowest: compounds 2, 1 and 4 (each within the scatter of the next). At a limit, above all of these: compound 3.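

In this assay, phenylsulfanyl in place of anilino on a saturated chain carbon bound to a triple-bonded carbon gives an at least 14-fold lower number from compound 3 to compound 4 (1.16 log units; beyond the scatter), so the sharp loss at this position does not extend to the sulfur-linked phenyl group and remains confined to compound 3. Phenylsulfanyl in place of phenoxy gives a 1.5-fold higher number from compound 1 to compound 4 (0.18 log units; within the scatter), and in place of benzyl gives a 1.7-fold higher number from compound 2 to compound 4 (0.23 log units; within the scatter), so compound 1, compound 2 and compound 4 cannot be told apart here, and compound 3 is the sole exception among the four. The size of the step from anilino to phenylsulfanyl is only a bound, as compound 3 stands at a limit of the assay and not at a number: the limit of > 40000 nM in this assay, at which 1 of the 4 values shown sits.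

The change from anilino to phenylsulfanyl also goes from 1 hydrogen-bond donor to 0, but the compounds shown do not separate that difference from the change of atom itself, and an N-methylanilino group at the same place would bear directly on this. Going by these compounds, it also remains open whether a longer chain between the triple-bonded carbon and the phenyl group, or a fluoro or methoxy group on the phenyl ring, would move the number away from the level shared by compound 1, compound 2 and compound 4.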